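The source may hold more compounds than are shown below. What is called first, only, known or untested is meant among the compounds shown, and "the series" means these compounds.

Measured compounds:
compound 1, `CNS(=O)(=O)Cc1noc2ccc(F)cc12` – 35 mg/kg
compound 2, `CCNS(=O)(=O)Cc1noc2ccc(F)cc12` – 32 mg/kg
compound 3, `CCNS(=O)(=O)Cc1noc2ccc(Cl)cc12` – 21 mg/kg

All three numbers come from a functional assay on the whole organism (strain STD-dd) with Mus musculus as the target, in the maximal electroshock model, with a stated time of 2 h; on this read-out higher numbers stand for an effect only at larger amounts of compound and lower numbers for an effect already at smaller amounts. The change from compound 1 to compound 2 is methyl in place of hydrogen on a saturated chain carbon bound to a sulfonamide nitrogen; the step that went with it is a 1.1-fold lower number from compound 1 to compound 2 (0.04 log units; within the scatter). From compound 2 to compound 3 the change is chloro in place of fluoro on an aromatic carbon, and the step is a 1.5-fold lower number from compound 2 to compound 3 (0.18 log units; within the scatter). Compound 4, `CC(C)NS(=O)(=O)Cc1noc2ccc(Cl)cc12`, has not been measured yet. It differs from compound 3 by methyl in place of hydrogen on a saturated chain carbon bound to a saturated chain carbon and a sulfonamide nitrogen. Going by the values given here, this is the same kind of change as the one from compound 1 to compound 2, but not the same: here the saturated chain carbon that takes the methyl is bound to a saturated chain carbon and a sulfonamide nitrogen, whereas in compound 1 that carbon is bound to a sulfonamide nitrogen only. The difference between the core of compound 1 and the core of compound 3 is not broken down here. The earlier step of a 1.1-fold lower number from compound 1 to compound 2 (0.04 log units; within the scatter) stayed within the scatter, so in this assay a step of similar size is expected for compound 4: a 1.1-fold lower number from compound 3 to compound 4 (0.02 log units; within the scatter). Compound 4 is therefore estimated at 20 mg/kg, with a likely range from 10 mg/kg to 40 mg/kg.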

Compound 4, dose for half-maximal effect: 100 mg/kg
Beside the measured number, compound 4's estimate is 5.0-fold (0.70 log units) below it; the whole stated range lies below it.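

In this assay, methyl in place of hydrogen on a saturated chain carbon bound to a saturated chain carbon and a sulfonamide nitrogen gave a 4.8-fold higher number from compound 3 to compound 4 (0.68 log units; beyond the scatter), so the small earlier step did not carry over to this core: the same change on two cores in this assay, a 1.1-fold lower number (0.04 log units; within the scatter) from compound 1 to compound 2 and a 4.8-fold higher number (0.68 log units; beyond the scatter) from compound 3 to compound 4, 5.2-fold (0.72 log units) apart, beyond the scatter of two such steps

A step seen on one core was therefore a poor guide to the related step on the other core in this series. What this does not show is which difference matters, since the two steps differ both in the carbon that takes the methyl and in the core, and a single pair of compounds for each step cannot pull those apart.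

As far as these compounds go, it stays open whether isopropylamino on the core of compound 1 would give a step as large as the one on the core of compound 3, which would tell whether that step goes with the isopropyl group alone or needs the chloro. From the compounds shown here alone, how a propyl chain or a tert-butyl group bound to the sulfonamide nitrogen would read is also open.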